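Extending the methoxy group of compound 1 to benzyl

The source may hold more compounds than are shown below. What is called first, only, known or untested is meant among the compounds shown, and "the series" means these compounds.

Measured so far in a functional assay on brain (Rattus norvegicus, strain Wistar) for inhibition; on this read-out lower numbers stand for stronger inhibition and higher numbers for weaker inhibition:
Compound 1 `COc1ccc(-c2c(C)[nH]c(=O)n2C)cc1`: 147000 nM
Compound 2 `Cc1[nH]c(=O)n(C)c1-c1ccc(C(C)(C)C)cc1`: 8400 nM
Compound 3 `CCCCCCCc1ccc(-c2c(C)[nH]c(=O)n2C)cc1`: 8400 nM

Compound 1 has the highest number of these three and so is the weakest inhibitor among them. Compound 4 `Cc1[nH]c(=O)n(C)c1-c1ccc(OCc2ccccc2)cc1` has not yet been measured. It keeps the core of compound 1 and differs from it by phenyl in place of hydrogen on a saturated chain carbon bound to an oxygen on an aromatic ring. Cut one bond further out, the same change reads methyl to benzyl.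

For the measured compounds named here, no measured step makes exactly this change, but two replace the same methoxy group. Tert-butyl gave an 18-fold lower number from compound 1 to compound 2 (1.24 log units; beyond the scatter), and heptyl gave an 18-fold lower number from compound 1 to compound 3 (1.24 log units; beyond the scatter). Those two replacements ended level, with no change at the digits printed from compound 2 to compound 3 (within the scatter). Both lose the oxygen that compound 4 retains, so they are only an indirect guide. They still point towards a lower number in this assay, and a somewhat smaller step is the cautious expectation. The expected change is a 9.8-fold lower number from compound 1 to compound 4 (0.99 log units; beyond the scatter). Compound 4 is estimated at 15000 nM. Its expected range runs from 3000 nM to 60000 nM.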

Compound 4, half-maximal inhibitory concentration: 6700 nM
Beside the measured number, compound 4's estimate is 2.2-fold (0.35 log units) above it; the range from low to high includes it.
By their numbers in this assay, from the lowest: compounds 4, 2 and 3 (each within the scatter of the next); then compound 1.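

In this assay, the change from methyl to benzyl, which puts phenyl in place of hydrogen on a saturated chain carbon bound to an oxygen on an aromatic ring, gives a 22-fold lower number from compound 1 to compound 4 (1.34 log units; beyond the scatter) and marks a large gain in inhibition. The earlier steps to compound 2 and compound 3 both removed the oxygen, so they could not show whether a lower number required its loss; compound 4 keeps that oxygen, and its number lies within the scatter of those of compound 2 and compound 3, so among these compounds a lower number does not depend on removing it. Nothing measured here explains why the added phenyl has this effect.

Tert-butyl, heptyl and benzyl are very different groups, yet compounds 2, 3 and 4 all end within the scatter of one another, which leaves open whether any change at this position can take the number much lower. As far as these compounds go, it also remains unknown how a longer chain carrying the phenyl, an amine in place of the phenyl, or a carboxylic acid on the phenyl would compare with benzyl.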